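Moving a Trifluoromethyl Group: What to Expect for Compound 4

The source may report more compounds than this note shows. Statements on the series, on what has been measured and on what is new or still open speak of the compounds shown alone.

Compound 1, `CC(O)(COc1cccc(C(F)(F)F)c1)C(=O)Nc1ccc(S(F)(F)(F)(F)F)cc1`, gives 24700 nM in a functional assay on LNCaP cells (Homo sapiens) for antiproliferative activity, read by propidium iodide staining, with a stated time of 96 h; on this read-out lower numbers stand for stronger inhibition and higher numbers for weaker inhibition.
Compound 2, `CC(O)(COc1ccccc1C(F)(F)F)C(=O)Nc1ccc(S(F)(F)(F)(F)F)cc1`, gives 1200 nM in this assay.
Compound 3, `CC(O)(COc1cccc(C(F)(F)F)c1)C(=O)Nc1cccc(S(F)(F)(F)(F)F)c1`, gives 28800 nM in this assay.

Compound 1 and compound 2 differ in one place only: 2-(trifluoromethyl)phenyl in place of 3-(trifluoromethyl)phenyl on an oxygen on a saturated carbon. That single change produced a 21-fold lower number from compound 1 to compound 2 (1.31 log units; beyond the scatter). Compound 3 shares the same ether part as compound 1 but carries a different core; the difference between the two cores is not broken down here. The numbers for compound 1 and compound 3 lie within the usual scatter of each other, so the two cores give no separable signal on their own.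

Compound 4, `CC(O)(COc1ccccc1C(F)(F)F)C(=O)Nc1cccc(S(F)(F)(F)(F)F)c1`, has not yet been measured. It stands to compound 3 as compound 2 stands to compound 1: 2-(trifluoromethyl)phenyl in place of 3-(trifluoromethyl)phenyl on an oxygen on a saturated carbon, at a place described in the same words, so it is the same change. If the change carries over, the expected step for compound 4 is a 19-fold lower number from compound 3 to compound 4 (1.28 log units; beyond the scatter), resting on the one measured instance a 21-fold lower number from compound 1 to compound 2 (1.31 log units; beyond the scatter). Since a single pair is a thin basis, the estimate for compound 4 in this assay is 1500 nM, expected to fall between 500 nM and 5000 nM.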

Compound 4, half-maximal inhibitory concentration: 26300 nM
Compound 4: middle estimate off by 18-fold (1.24 log units), on the low side; measured number outside the range, above it.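

In this assay, putting 2-(trifluoromethyl)phenyl in place of 3-(trifluoromethyl)phenyl on the core of compound 3 gives a 1.1-fold lower number from compound 3 to compound 4 (0.04 log units; within the scatter), so on this core the change has no effect that can be told apart from the scatter. Set beside the earlier step, the same change does not carry over from one core to the other, and the size of its effect depends on which core bears it: the same change on two cores in this assay, a 21-fold lower number (1.31 log units; beyond the scatter) from compound 1 to compound 2 and a 1.1-fold lower number (0.04 log units; within the scatter) from compound 3 to compound 4, 19-fold (1.27 log units) apart, beyond the scatter of two such steps. Within the data shown here, these two pairs show only that a large step on one core does not guarantee one on another; they do not show why the two cores differ, and they give no rule for any further core.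

The compounds shown leave open whether the large step is confined to the core of compound 1 or would also appear on other cores. Trifluoromethyl is also the only group shown on the ether's aromatic ring, so it remains open whether a chlorine or a nitrile in its place would depend on the core in the same way.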